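The compounds below may be only part of what the source reports. "The series", "measured", "known", "first", "only" and "open" are said of these compounds alone.

Measured compounds:
compound 1 `Cc1ccc(NC(=O)c2ccc(/N=N\c3c[nH]c4ccccc34)cc2)cc1`: 25400 nM
compound 2 `Cc1ccc(C)c(NC(=O)c2ccc(/N=N\c3c[nH]c4ccccc34)cc2)c1`: 544000 nM
compound 3 `O=C(Nc1cccc(Cl)c1)c1ccc(/N=N\c2c[nH]c3ccccc23)cc1`: 80000 nM

In a functional assay on HCT-116 cells (Homo sapiens) for inhibition, read by MTT assay, with a stated time of 72 h (a higher number here means a weaker inhibitor, a lower number a stronger inhibitor), compound 1 gives the lowest number of the three; compound 3 is the nearest, the step being a 3.1-fold higher number from compound 1 to compound 3 (0.50 log units; beyond the scatter), and compound 2 the furthest, with a 21-fold higher number from compound 1 to compound 2 (1.33 log units; beyond the scatter). Compound 4 `Cc1ccccc1NC(=O)c1ccc(/N=N\c2c[nH]c3ccccc23)cc1` differs from compound 1 by 2-methylphenyl in place of 4-methylphenyl on an amide-type nitrogen. The step that bears most on this is a 21-fold higher number from compound 1 to compound 2 (1.33 log units; beyond the scatter), since the 2,5-dimethylphenyl of compound 2 is the closest measured analogue of 2-methylphenyl; the step of a 3.1-fold higher number from compound 1 to compound 3 (0.50 log units; beyond the scatter) shows that other changes to this phenyl also raise the number, though less. A step upward beyond the scatter is therefore expected, though smaller than for compound 2. For compound 4 the estimate is 150000 nM (range 40000 nM to 600000 nM), meaning an expected step of a 5.9-fold higher number from compound 1 to compound 4 (0.77 log units; beyond the scatter).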

Compound 4, half-maximal inhibitory concentration: 509000 nM
For compound 4 the middle estimate is 3.4-fold (0.53 log units) below the measured one; the measured number falls inside the stated range.
By their numbers in this assay, from the lowest: compound 1; then compound 3; then compounds 4 and 2 (each within the scatter of the next).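

In this assay, 2-methylphenyl in place of 4-methylphenyl alone gives a 20-fold higher number from compound 1 to compound 4 (1.30 log units; beyond the scatter), so a single methyl, differently placed, is enough for a large step. Hydrogen in place of the further methyl gives a 1.1-fold lower number from compound 2 to compound 4 (0.03 log units; within the scatter), so that methyl adds no readable difference, while 2-methylphenyl in place of 3-chlorophenyl gives a 6.4-fold higher number from compound 3 to compound 4 (0.80 log units; beyond the scatter). No measurement shown here explains these steps. Open, on these data alone, is whether the step belongs to methyl specifically or to any group there. A methoxy group or an amine in place of that methyl would test this.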